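Dropping the Chloro Group from a Weakly Active Piperazine Series

A few compounds are considered here, and "the series" means these few. Any claim that something is new, unique, unknown or untested is made for them only; others in the source may bear on it.

Three compounds have been measured in a functional assay on HeLa cells (Homo sapiens) for antiproliferative activity, read by MTT assay, with a stated time of 48 h; on this read-out lower numbers stand for stronger inhibition and higher numbers for weaker inhibition:
Compound 1 `O=[N+]([O-])c1ccc(N2CCN(Cn3nc(-c4ccc5c(c4)OCCO5)oc3=S)CC2)cc1` gives 31700 nM.
Compound 2 `S=c1oc(-c2ccc3c(c2)OCCO3)nn1CN1CCN(c2ccccc2Cl)CC1` gives 37400 nM.
Compound 3 `S=c1oc(-c2ccc3c(c2)OCCO3)nn1CN1CCN(c2cccc(Cl)c2)CC1` gives 47200 nM.

Compound 3 has the highest of the three numbers on paper, yet the gaps to its neighbours are within the scatter: a 1.5-fold higher number from compound 1 to compound 3 (0.17 log units; within the scatter) and a 1.3-fold higher number from compound 2 to compound 3 (0.10 log units; within the scatter) are both small, as is a 1.2-fold higher number from compound 1 to compound 2 (0.07 log units; within the scatter). Exchanging one substituted phenyl for another on the amine nitrogen in the ring has thus left this assay essentially unmoved across these three compounds, all of which sit at weak inhibition.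

Compound 4 `S=c1oc(-c2ccc3c(c2)OCCO3)nn1CN1CCN(c2ccccc2)CC1` differs from compound 3 in a single place: hydrogen in place of chloro on an aromatic carbon. Going by the values given here, none of the measured steps removes a substituent from that phenyl altogether; they only swap one substituted phenyl for another, and each stayed within the scatter. With nothing to suggest otherwise, the step of a 1.0-fold lower number from compound 3 to compound 4 (0.02 log units; within the scatter) is expected to remain within the scatter as well. Compound 4 is therefore estimated at 45000 nM, with a likely range from 22000 nM to 90000 nM.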

Compound 4, half-maximal inhibitory concentration: > 50000 nM
Compound 4: no number, only a limit; the forecaster's own chance of this, stated with the estimate: 10%; at least 1.1-fold (0.04 log units) between middle value and limit.
By their numbers in this assay, from the lowest: compounds 1, 2 and 3 (each within the scatter of the next). At a limit, above all of these: compound 4.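

In this assay compound 4 gives > 50000 nM, which is a limit of the assay and not a number. Its steps can be read only as floors, each within the scatter: an at least 1.0-fold higher number from compound 3 to compound 4 (0.02 log units; that floor lies within the scatter), an at least 1.3-fold higher number from compound 2 to compound 4 (0.12 log units; that floor lies within the scatter) and an at least 1.5-fold higher number from compound 1 to compound 4 (0.19 log units; that floor lies within the scatter). Taking the substituent away, leaving plain phenyl, thus brings no sign of stronger inhibition, but how far the true number lies past these floors cannot be told, because the reading stops at a limit: the limit of > 50000 nM in this assay, at which 1 of the 4 values shown sits.

As far as these compounds go, what a methoxy group, an amine or a carboxylic acid on that same aromatic carbon would do stays open. From the compounds shown here alone, it also stays open whether any change to this phenyl, rather than to the shared core, can move the series away from weak inhibition.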